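This account rests on a few compounds, and the source may have more. Where it says the series, first, only, none or still open, it means among the compounds named here.

Working notes on the series in a toxicity assay on CHO-K1 cells (Cricetulus griseus) for cytotoxicity, read by MTT assay, with a stated time of 48 h; on this read-out higher numbers stand for weaker inhibition and lower numbers for stronger inhibition. Compound 1 `COc1cc(/C=C/C(=O)/C=C(/C=C/c2ccc(O)c(OC)c2)NCCO)ccc1O` gives 87500 nM and compound 3 `COc1cc(/C=C/C(=O)/C=C(/C=C/c2ccc(O)c(OC)c2)NCCCO)ccc1O` gives 88500 nM, and these two numbers lie within the scatter of each other. Compound 2 `COCCCN1C(/C=C/c2ccc(O)cc2)=CC(=O)CC1c1ccc(O)cc1` reads > 100000 nM, which is a limit of the assay and not a number. For the measured compounds named here, compound 3 therefore stands level with compound 1, and the only other reading is the limit of > 100000 nM in this assay, at which 1 of the 3 values shown sits.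

Compound 4 `COCCNC(=C\C(=O)/C=C/c1ccc(O)c(OC)c1)/C=C/c1ccc(O)c(OC)c1` is unmeasured. It keeps the shared core of compound 3 and changes the side chain from (3-hydroxypropyl)amino to (2-methoxyethyl)amino: methoxy in place of hydroxymethyl on a saturated chain carbon, two bonds along the chain from an amine nitrogen.

Going by the values given here, the one measured step at this place is a 1.0-fold higher number from compound 1 to compound 3 (0.00 log units; within the scatter), with hydroxymethyl in place of hydroxy, and it stays within the scatter. Among the compounds with values here, no measured pair on this core tests methoxy in place of hydroxymethyl, so that step is only a loose guide. On this single flat step, no change beyond the scatter is expected in this assay, in either direction. The estimated step is a 1.0-fold lower number from compound 3 to compound 4 (0.02 log units; within the scatter). A reading reported only as a limit would also not be a surprise for this compound. The expected value for compound 4 is 85000 nM, with an estimated range of 45000 nM to 100000 nM.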

Compound 4, half-maximal inhibitory concentration: 63000 nM
For compound 4 the middle estimate is 1.3-fold (0.13 log units) above the measured one; the range from low to high includes it.
By their numbers in this assay, from the lowest: compounds 4, 1 and 3 (each within the scatter of the next). At a limit, above all of these: compound 2.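

In this assay, methoxy in place of hydroxymethyl on a saturated chain carbon, two bonds along the chain from an amine nitrogen, gives a 1.4-fold lower number from compound 3 to compound 4 (0.15 log units; within the scatter), and methyl in place of hydrogen on an oxygen on a saturated carbon gives a 1.4-fold lower number from compound 1 to compound 4 (0.14 log units; within the scatter). The earlier pair changed only the length of a hydroxy-ended side chain, whereas here the hydrogen-bond donor of the hydroxymethyl leaves, and the reading of compound 4 still lies within the scatter of both compound 1 and compound 3, so on the shared core that free hydroxy is not needed to hold the reading at this level. No measurement shown gives a cause for these readings.

As far as these compounds go, whether an amine or a carboxylic acid at the end of the side chain, or a longer chain, would move the reading beyond the scatter stays open. Also open is whether these side chains would separate in any read-out other than this assay, since the compounds shown offer no second assay to compare.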